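The source may hold more compounds than are shown below. What is called first, only, known or untested is meant among the compounds shown, and "the series" means these compounds.

For the measured compounds named here, compound 1, with the structure `O=C(/C=C/c1cccs1)c1cc(O)c(O)c([N+](=O)[O-])c1`, is one of two compounds measured in an assay on isolated protein for inhibition of Amine oxidase [flavin-containing] A (Homo sapiens), read by fluorescence (a higher number here means a weaker inhibitor, a lower number a stronger inhibitor), where compound 1 gives 49900 nM. The second compound, compound 2, has the structure `CC(=O)N1N=C(c2cc(O)c(O)c([N+](=O)[O-])c2)CC1c1cccs1` and in this assay compound 2 gives 86300 nM. Compound 1 holds the lower of the two numbers, but the value of compound 2 is within the usual scatter of repeated measurements of it, so the two cannot be told apart on this evidence. Going by the values given here, no pair of measured compounds differing in a single place is available, so nothing measured here shows how far one change at the chain end can move the number.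

Compound 3, with the structure `O=C(/C=C/c1nccs1)c1cc(O)c(O)c([N+](=O)[O-])c1`, is not yet measured. It differs from compound 1 in one place: 1,3-thiazol-2-yl in place of thiophen-2-yl on a double-bonded chain carbon bound to a double-bonded chain carbon. The shared core of compound 1 is kept unchanged. Among the compounds with values here, with no measured step to lean on, the step from compound 1 to compound 3 in this assay is expected to be a 1.2-fold higher number from compound 1 to compound 3 (0.08 log units; within the scatter), that is, no change beyond the scatter, in either direction. Compound 3 is therefore estimated to give 60000 nM in this assay, in a range from 20000 nM to 180000 nM.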

Compound 3, half-maximal inhibitory concentration: 69600 nM
Beside the measured number, compound 3's estimate is 1.2-fold (0.06 log units) below it; low and high end bracket the measured number.
By their numbers in this assay, from the lowest: compounds 1, 3 and 2 (each within the scatter of the next).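

For the compounds shown here, the step of a 1.4-fold higher number from compound 1 to compound 3 (0.14 log units; within the scatter) in this assay is the first measured exchange at one place in this set, on a double-bonded chain carbon bound to a double-bonded chain carbon. It shows that 1,3-thiazol-2-yl and thiophen-2-yl cannot be told apart at this position in this assay, although the ring goes from 1 hetero atom to 2 hetero atoms and from 1 hydrogen-bond acceptor to 2 hydrogen-bond acceptors, with the heavy-atom count the same. Nothing measured here offers an explanation for this result.

Both groups compared are five-membered aromatic rings, so this one step says nothing about how far the number can move when a different kind of group stands at this place, such as a phenyl ring, an amine, a carboxylic acid or a longer chain. It also leaves open whether 1,3-thiazol-2-yl in place of thiophen-2-yl would read the same way on the core of compound 2, and whether any exchange at this position can carry the number beyond the scatter.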